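Removing a Dimethylamino Group from a Weak Antiproliferative Lead

A few compounds are considered here, and "the series" means these few. Any claim that something is new, unique, unknown or untested is made for them only; others in the source may bear on it.

Compound 1 `CCCSc1nc(N/N=C/c2ccc(N(C)C)cc2)c2nnn(Cc3ccccc3)c2n1` is the weaker of two measured compounds in a functional assay on ECa-109 cells (Homo sapiens) for antiproliferative activity, read by MTT assay, with a stated time of 72 h (on this read-out lower numbers stand for stronger inhibition and higher numbers for weaker inhibition), giving 20000 nM, while compound 2 `C#CCSc1nc(N/N=C(\C)c2ccccc2O)c2nnn(Cc3ccccc3)c2n1` gives 5250 nM in this assay. The unmeasured compound 3 `CCCSc1nc(N/N=C/c2ccccc2)c2nnn(Cc3ccccc3)c2n1` differs from compound 1 in one place: hydrogen in place of dimethylamino on an aromatic carbon. Among the measured compounds shown here, no measured pair shows what such a change does here, so the direction is open. Without that guide, compound 3 is expected to land close to compound 1, and the expected step of no change at the digits printed from compound 1 to compound 3 (within the scatter) should stay within the scatter. Compound 3 is therefore estimated at 20000 nM, within a range of 7000 nM to 60000 nM.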

Compound 3, half-maximal inhibitory concentration: > 64000 nM
Compound 3: only a limit was reported; the forecaster's own chance of this, stated with the estimate: 20%; middle value at least 3.2-fold (0.50 log units) away from the limit.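

In this assay, the change from 4-(dimethylamino)phenyl to phenyl gives an at least 3.2-fold higher number from compound 1 to compound 3 (0.50 log units; beyond the scatter), so inhibition weakens when dimethylamino leaves. Among the compounds shown here, this is the first sign that this position on the ring matters: weak as compound 1 is, its dimethylamino group is not dispensable. The value of compound 3, > 64000 nM, is a limit of the assay and not a number.

One group and hydrogen cannot show which feature of dimethylamino counts. As far as these compounds go, a plain amino group or a methoxy group at this place could separate these possibilities, and whether any group here brings stronger inhibition than compound 1 remains open.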